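Terminal chain variation in a prostanoid series: compound 4

The compounds below may be only part of what the source reports. "The series", "measured", "known", "first", "only" and "open" are said of these compounds alone.

Measured so far:
compound 1 `COC(=O)CC/C=C\CC[C@H]1C(=O)C[C@@H](O)[C@@H]1/C=C/C[C@@](C)(O)/C=C/C(C)=C(C)C` gives 0.00006 mg/kg in a functional assay on the whole organism with Canis familiaris (Canis lupus familiaris) as the target; a lower number here means that less compound is needed, a higher number that more compound is needed for the effect;
compound 2 `C/C=C(C)\C=C\[C@](C)(O)C/C=C/[C@H]1[C@H](O)CC(=O)[C@@H]1CC/C=C\CCC(=O)OC` gives 0.000016 mg/kg;
compound 3 `COC(=O)CC/C=C\CC[C@H]1C(=O)C[C@@H](O)[C@@H]1/C=C/C[C@@](C)(O)/C=C/C1=CCCC1` gives 0.00002 mg/kg.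

Compound 3 stands second highest of the three numbers; its nearest neighbour is compound 2, within the scatter, and its furthest is compound 1, with a 3.0-fold lower number from compound 1 to compound 3 (0.48 log units; beyond the scatter).

Compound 4 `CCCCC(C)(O)C/C=C/[C@H]1[C@H](O)CC(=O)[C@@H]1CC/C=C\CCC(=O)OC` differs from compound 3 by 1-hydroxy-1-methylpentyl in place of 3-(cyclopent-1-en-1-yl)-1-hydroxy-1-methylprop-2-en-1-yl on a saturated chain carbon bound to a double-bonded chain carbon. The measured steps of a 3.8-fold lower number from compound 1 to compound 2 (0.57 log units; beyond the scatter) and a 3.0-fold lower number from compound 1 to compound 3 (0.48 log units; beyond the scatter) only exchange one alkenyl group for another and bear on this step only loosely; none removes the whole unsaturated extension. Without a close precedent, a modest rise in the number is expected, with wide uncertainty.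

For compound 4 the estimate is 0.0001 mg/kg, between 0.00002 mg/kg and 0.0006 mg/kg, which means an expected step of a 5.0-fold higher number from compound 3 to compound 4 (0.70 log units; beyond the scatter).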

Compound 4, dose for half-maximal effect: 0.000023 mg/kg
For compound 4 the middle estimate is 4.3-fold (0.64 log units) above the measured one; the measured number falls inside the stated range.
By their numbers in this assay, from the lowest: compounds 2, 3 and 4 (each within the scatter of the next); then compound 1.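

In this assay the whole unsaturated extension on this saturated chain carbon can give way to 1-hydroxy-1-methylpentyl with no change beyond the scatter (a 1.2-fold higher number from compound 3 to compound 4 (0.06 log units; within the scatter)) and (a 1.4-fold higher number from compound 2 to compound 4 (0.16 log units; within the scatter)). Against 1-hydroxy-1,4,5-trimethylhexa-2,4-dien-1-yl, the same group lowers the number (a 2.6-fold lower number from compound 1 to compound 4 (0.42 log units; beyond the scatter)). Among these compounds, neither the cyclopentene ring nor the diene is needed here, and only the group of compound 1 stands apart.

No measured evidence accounts for this tolerance. On these data alone, whether a longer chain, a phenyl ring or an amine at this place keeps the number in this range remains open.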